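The source may report more compounds than this note shows. Statements on the series, on what has been measured and on what is new or still open speak of the compounds shown alone.

In a functional assay on KYSE-70 cells for antiproliferative activity against KYSE-70 cell line (Homo sapiens), read by MTT assay, with a stated time of 72 h (a lower number here means a stronger inhibitor, a higher number a weaker inhibitor), compound 1 `O=C(c1ccnc2cc(Br)ccc12)N1CCCCC1` gives > 20000 nM, a limit of the assay. Compound 2 `COc1ccc(OC)c(NC(=O)c2cc(=O)[nH]c3cc(Br)ccc23)c1` gives > 20000 nM, also a limit. Compound 3 `COc1cccc(NC(=O)c2cc(=O)[nH]c3cc(Br)ccc23)c1` gives > 20000 nM, again a limit, so it has no number of its own. All three compounds sit at the same point: the limit of > 20000 nM in this assay, at which 3 of the 3 values shown sit.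

Compound 4 `O=C(Nc1cccc(OC(F)(F)F)c1)c1cc(=O)[nH]c2cc(Br)ccc12` departs from compound 3 by one change: trifluoromethyl in place of methyl on an oxygen on an aromatic ring. In short, this is methoxy to trifluoromethoxy, with trifluoromethyl in place of methyl on an oxygen on an aromatic ring.

Among the compounds with values here, the only measured step involving a methoxy group is a step that the two limits leave unreadable from compound 2 to compound 3, with hydrogen in place of methoxy on an aromatic carbon. It gives no size or direction to carry over, so no step beyond the scatter can be forecast. The expected step in this assay is a number no higher from compound 3 to compound 4 (the limit leaves the size open), with no direction favoured. Compound 4 is expected to be reported most likely as a limit as well. The estimate for compound 4 is 20000 nM, with an expected range from 8000 nM to 40000 nM.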

Compound 4, half-maximal inhibitory concentration: > 20000 nM
Compound 4 gave a limit, no number (the forecaster's own chance of this, stated with the estimate: 75%); the middle value lies on the limit itself.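

Compound 3 and compound 4 both stand at a limit, so the change from methoxy to trifluoromethoxy gives no readable step. The compounds shown leave open how far any of them lies past that limit, and which structural change would bring a measurable value: the limit of > 20000 nM in this assay, at which 4 of the 4 values shown sit.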